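The source may hold more compounds than are shown below. What is called first, only, known or untested is meant among the compounds shown, and "the series" means these compounds.

Compound 1 `COc1ccc(OC)c(/C=C/C(=O)Nc2cc3c(Nc4ccc(F)c(Cl)c4)ncnc3cc2O[C@H]2CCOC2)c1`: 26800 nM
Compound 2 `COc1cc(/C=C/C(=O)Nc2cc3c(Nc4ccc(F)c(Cl)c4)ncnc3cc2OC)cc(OC)c1`: "not determined" (no result reported)
Compound 3 `COc1cc(/C=C/C(=O)Nc2cc3c(Nc4ccc(F)c(Cl)c4)ncnc3cc2O[C@H]2CCOC2)cc(OC)c1`: 34300 nM

In a functional assay on HeLa cells (Homo sapiens) for cytotoxicity, read by MTT assay, with a stated time of 72 h (a lower number here means a stronger inhibitor, a higher number a weaker inhibitor), compound 3 gives 34300 nM. In this assay compound 1 gives 26800 nM. The two numbers differ only by a 1.3-fold higher number from compound 1 to compound 3 (0.11 log units; within the scatter), which is within the scatter, so nothing separates compound 3 from compound 1. For compound 2 the result in this assay is "not determined" (no result reported).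

Compound 4 `O=C(/C=C/c1ccc(F)cc1Cl)Nc1cc2c(Nc3ccc(F)c(Cl)c3)ncnc2cc1O[C@H]1CCOC1` is the next compound to consider. It differs from compound 3 in one place: 2-chloro-4-fluorophenyl in place of 3,5-dimethoxyphenyl on a double-bonded chain carbon bound to a double-bonded chain carbon. Going by the values given here, no measured step bears on this kind of change. Among the compounds with values here, the only step available, from compound 1 to compound 3, moves a methoxy group around the same ring and stays within the scatter; it says nothing about replacing both methoxy groups with halogens. With no guidance, no step beyond the scatter is expected, and the estimated change a 1.1-fold lower number from compound 3 to compound 4 (0.06 log units; within the scatter) is put close to nothing. Compound 4 is therefore estimated at 30000 nM in this assay, with a range from 9000 nM to 100000 nM to reflect how little is known.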

Compound 4, half-maximal inhibitory concentration: 37500 nM
Compound 4: the middle estimate sits 1.3-fold (0.10 log units) below what was measured; the measured number falls inside the stated range.
By their numbers in this assay, from the lowest: compounds 1, 3 and 4 (each within the scatter of the next).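

In this assay, replacing 3,5-dimethoxyphenyl with 2-chloro-4-fluorophenyl on the double-bonded chain carbon gives a 1.1-fold higher number from compound 3 to compound 4 (0.04 log units; within the scatter), and replacing 2,5-dimethoxyphenyl with the same group gives a 1.4-fold higher number from compound 1 to compound 4 (0.15 log units; within the scatter). Moving a methoxy group had already left the number within the scatter, and now even exchanging both methoxy groups for a chlorine and a fluorine sets none of compounds 1, 3 and 4 apart. No measurement is available to explain this result.

From the compounds shown here alone, whether any group at this position can shift the number remains open, for example a phenyl ring carrying an amine or a carboxylic acid, or a longer chain in place of the ring. Steps involving compound 2 cannot be read, as it has no reported result.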